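This account rests on a few compounds, and the source may have more. Where it says the series, first, only, none or still open, it means among the compounds named here.

- Compound 1 `N#Cc1ccc(NC(=O)c2cc(-c3ccncc3)ccc2O)cc1`: 7990 nM
- Compound 2 `N#Cc1ccc(NC(=O)c2cc(-c3cccnc3)ccc2O)cc1`: 8330 nM
- Compound 3 `N#Cc1ccc(NC(=O)c2cc(Cl)ccc2O)cc1`: 1860 nM

All three compounds were tested in a functional assay on KG-1 cells (Homo sapiens) for cytotoxicity, read by luminescence and CellTiter-Glo, with a stated time of 3 days; a higher number here means a weaker inhibitor, a lower number a stronger inhibitor. Compound 3 stands lowest of the three at 1860 nM, and both steps leading to it are modest but beyond the scatter: a 4.3-fold lower number from compound 1 to compound 3 (0.63 log units; beyond the scatter) and a 4.5-fold lower number from compound 2 to compound 3 (0.65 log units; beyond the scatter). Exchanging pyridin-4-yl for pyridin-3-yl made no real difference, with a 1.0-fold higher number from compound 1 to compound 2 (0.02 log units; within the scatter).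

Compound 4 `Cc1ccc(O)c(C(=O)Nc2ccc(C#N)cc2)c1` is still unmeasured. It differs from compound 3 by methyl in place of chloro on an aromatic carbon, with methyl in place of chloro on an aromatic carbon, para to a hydroxy group. For the measured compounds named here, no measured step makes this exchange, so the evidence is indirect. The nearest guide is the pair of steps above, a 4.3-fold lower number from compound 1 to compound 3 (0.63 log units; beyond the scatter) and a 4.5-fold lower number from compound 2 to compound 3 (0.65 log units; beyond the scatter), where a ring-bearing group left and chloro entered. Methyl, like chloro, has no ring, so a smaller step than those is expected in this assay, probably towards a higher number and perhaps within the scatter. The expected change is a 1.6-fold higher number from compound 3 to compound 4 (0.21 log units; within the scatter). For compound 4 the estimated value is 3000 nM, with an expected range from 1200 nM to 8000 nM.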

Compound 4, half-maximal inhibitory concentration: 3370 nM
Beside the measured number, compound 4's estimate is 1.1-fold (0.05 log units) below it, and the stated range covers the measured number.
By their numbers in this assay, from the lowest: compounds 3 and 4 (each within the scatter of the next); then compounds 1 and 2 (each within the scatter of the next).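

In this assay, methyl at the position para to a hydroxy group reads the same as chloro within the scatter (a 1.8-fold higher number from compound 3 to compound 4 (0.26 log units; within the scatter)), so this exchange between two groups without a ring leaves the number essentially unmoved. The earlier compounds shown here showed a lower number on leaving a pyridine ring only for chloro, and methyl now shows it too, with a 2.4-fold lower number from compound 1 to compound 4 (0.37 log units; beyond the scatter) and a 2.5-fold lower number from compound 2 to compound 4 (0.39 log units; beyond the scatter) as modest steps. No measurement at hand explains these numbers.

Still open, from the compounds shown here alone, is whether an amine, a carboxylic acid or a longer chain at this position would read like methyl and chloro or like the pyridine compounds. Also open, going by these compounds, is whether a plain phenyl ring would bring the higher number seen with pyridin-3-yl and pyridin-4-yl.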